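Trifluoromethoxy for Trifluoromethyl on a Second Core

This account rests on a few compounds, and the source may have more. Where it says the series, first, only, none or still open, it means among the compounds named here.

Three compounds have been measured in a functional assay on A2780 cells (Homo sapiens) for inhibition, with a stated time of 72 h; on this read-out higher numbers stand for weaker inhibition and lower numbers for stronger inhibition:

Compound 1 `CC1(C)CCNc2ccc(NC(=S)Nc3ccc(C(F)(F)F)cc3)cc21`: 6000 nM
Compound 2 `CC1(C)CCNc2ccc(NC(=S)Nc3ccc(OC(F)(F)F)cc3)cc21`: 7100 nM
Compound 3 `CN1c2ccc(NC(=O)Nc3ccc(C(F)(F)F)cc3)cc2C(C)(C)C(O)C1(C)C`: 6700 nM

Compound 1 and compound 2 share one core and differ in a single place, (trifluoromethoxy in place of trifluoromethyl on an aromatic carbon). That change gave a 1.2-fold higher number from compound 1 to compound 2 (0.07 log units; within the scatter). Compound 3 is built on another core; the difference between the two cores is not broken down here. The values of compound 1 and compound 3 lie within the scatter of each other, as do those of compound 2 and compound 3.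

Compound 4 `CN1c2ccc(NC(=O)Nc3ccc(OC(F)(F)F)cc3)cc2C(C)(C)C(O)C1(C)C` carries the same change on the core of compound 3, namely (trifluoromethoxy in place of trifluoromethyl on an aromatic carbon). Because the same change earlier gave a 1.2-fold higher number from compound 1 to compound 2 (0.07 log units; within the scatter), the step expected this time is a 1.1-fold higher number from compound 3 to compound 4 (0.05 log units; within the scatter). The value of compound 4 in this assay is therefore estimated at 7500 nM, most likely between 3500 nM and 16000 nM.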

Compound 4, half-maximal inhibitory concentration: 7800 nM
Compound 4: the middle estimate sits 1.0-fold (0.02 log units) below what was measured; the range from low to high includes it.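

On the second core, trifluoromethoxy in place of trifluoromethyl gave a 1.2-fold higher number from compound 3 to compound 4 (0.07 log units; within the scatter) in this assay. Set beside the earlier step, the change gives matching results on the two cores: the same change on two cores in this assay, a 1.2-fold higher number (0.07 log units; within the scatter) from compound 1 to compound 2 and a 1.2-fold higher number (0.07 log units; within the scatter) from compound 3 to compound 4, 1.0-fold (0.01 log units) apart, within the scatter of two such steps This shows that, on these two cores, the swap leaves the number within the scatter, but it does not show that a further core would behave the same way or explain why the two steps match.

All the compounds shown carry one of these two fluorinated groups on the aromatic ring, so what a nitrile, an amine or a carboxylic acid would do in that place stays open. On these data alone, the separate contribution of each difference between the two cores also stays open.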